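From Benzofuranyl to Pyrimidinyl: Estimating Compound 4

The compounds below may be only part of what the source reports. "The series", "measured", "known", "first", "only" and "open" are said of these compounds alone.

Measured compounds:
compound 1 `Cn1c(=O)c(S(=O)(=O)c2ccc(F)cc2)cc2cnc(Nc3ccc4occc4c3)nc21` gives 5000 nM
compound 2 `Cn1c(=O)c(S(=O)(=O)c2ccc(F)cc2F)cc2cnc(Nc3ccc4occc4c3)nc21` gives 15000 nM
compound 3 `Cc1ccc(S(=O)(=O)c2cc3cnc(Nc4ccc5cc[nH]c5c4)nc3n(C)c2=O)cc1` gives 15000 nM

In a functional assay on K562 cells (Homo sapiens) for inhibition, read by trypan blue exclusion, with a stated time of 72 h (on this read-out higher numbers stand for weaker inhibition and lower numbers for stronger inhibition), compound 2 gives 15000 nM, level with compound 3 at the digits shown and together with it the highest of the three numbers. Compound 1 sits lower; the step of a 3.0-fold higher number from compound 1 to compound 2 (0.48 log units; beyond the scatter) lies beyond the scatter and concerns a fluoro on an aromatic carbon on the sulfonyl side.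

Compound 4 `Cn1c(=O)c(S(=O)(=O)c2ccc(F)cc2F)cc2cnc(Nc3ccncn3)nc21` differs from compound 2 by pyrimidin-4-yl in place of 1-benzofuran-5-yl on a nitrogen on an aromatic ring. Among the compounds with values here, no measured step touches this part of the structure, so the one measured step gives no guide, and the expectation rests on the change alone. Exchanging the bicyclic 1-benzofuran-5-yl for pyrimidin-4-yl is expected to weaken inhibition, a 2.0-fold higher number from compound 2 to compound 4 (0.30 log units; within the scatter), with wide uncertainty. Compound 4 is estimated at 30000 nM, between 8000 nM and 100000 nM.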

Compound 4, half-maximal inhibitory concentration: 30000 nM
For compound 4 middle estimate and measured number coincide at the digits printed; measured number inside the range.
By their numbers in this assay, from the lowest: compound 1; then compounds 2, 3 and 4 (each within the scatter of the next).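

In this assay, within the data shown here, the nitrogen-bound group on the shared core changes for the first time, and pyrimidin-4-yl in place of 1-benzofuran-5-yl gives a 2.0-fold higher number from compound 2 to compound 4 (0.30 log units; within the scatter). So at this position, a single six-membered ring reads level with the fused bicyclic group. No measurement available here explains this result.

As far as these compounds go, what a phenyl ring carrying a piperazine or a morpholine would do on this nitrogen remains open. So does whether the fluoro effect seen on the sulfonyl side would hold alongside pyrimidin-4-yl.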